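The source may report more compounds than this note shows. Statements on the series, on what has been measured and on what is new or still open speak of the compounds shown alone.

Going by the values given here, in a functional assay on MDA-MB-231 cells (Homo sapiens) for cytotoxicity, read by MTT assay, with a stated time of 72 h (on this read-out lower numbers stand for stronger inhibition and higher numbers for weaker inhibition), compound 1 (`Cc1ccc(NC(=O)CN2CCN(c3nnc(Cc4ccncc4)c4ccccc34)CC2)c(C)c1`) gives 240 nM, the lower of the two numbers measured so far. The other measured compound, compound 2 (`Cc1ccc(F)cc1NC(=O)CN1CCN(c2nnc(Cc3ccccc3)c3ccccc23)CC1`), gives 19200 nM, a gap well beyond the usual scatter. Compound 3 (`O=C(CN1CCN(c2nnc(Cc3ccncc3)c3ccccc23)CC1)Nc1c(F)cccc1F`) is still unmeasured. It differs from compound 1 by 2,6-difluorophenyl in place of 2,4-dimethylphenyl on an amide-type nitrogen, with 2,6-difluorophenyl in place of 2,4-dimethylphenyl on an amide-type nitrogen. Two values cannot isolate the effect of this one change, so the expectation is loose: a moderately weaker result, beyond the scatter, with an estimated step of a 4.2-fold higher number from compound 1 to compound 3 (0.62 log units; beyond the scatter). For compound 3 the estimated value is 1000 nM, within a range of 150 nM to 8000 nM.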

Compound 3, half-maximal inhibitory concentration: 1900 nM
Beside the measured number, compound 3's estimate is 1.9-fold (0.28 log units) below it; low and high end bracket the measured number.
By their numbers in this assay, from the lowest: compound 1; then compound 3; then compound 2.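

In this assay the swap of 2,4-dimethylphenyl for 2,6-difluorophenyl on the amide-type nitrogen gives a 7.9-fold higher number from compound 1 to compound 3 (0.90 log units; beyond the scatter) and so shows that this position is sensitive to the groups on the ring, even though the two rings have the same heavy-atom count and neither adds a hydrogen-bond donor or acceptor. Nothing available explains this difference.

From the compounds shown here alone, the methyl groups and fluorines change together here, so their separate contributions stay open. Also open, going by these compounds, is how a plain phenyl or a cyclohexyl on this nitrogen would compare.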